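Swapping a Pyridine Ring for Methoxyphenyl: Toxicity Outlook

The source may report more compounds than this note shows. Statements on the series, on what has been measured and on what is new or still open speak of the compounds shown alone.

Measured compounds:
compound 1, `COC(=O)c1cc(-c2cccc(NC(=O)c3ccc(/C=C/C(=O)c4cc(OC)c(OC)c(OC)c4)cc3)c2)on1`, in an ADME assay on Vero cells (Chlorocebus sabaeus) for cytotoxicity, read by MTT assay, with a stated time of 72 h (on this read-out higher numbers stand for lower toxicity in this test and lower numbers for higher toxicity in this test), gives > 50 ug/mL.
compound 2, `COC(=O)c1cc(-c2cccc(NC(=O)c3ccc(/C=C/C(=O)c4cccnc4)cc3)c2)on1`, in this assay gives "not determined" (no result reported).

The value for compound 1 is a limit of the assay, not a number. Compound 2 has no number of its own in this assay, so nothing places it on a scale. The one clue the data give is the limit of > 50 ug/mL in this assay, at which 1 of the 2 values shown sits.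

Compound 3, `COC(=O)c1cc(-c2cccc(NC(=O)c3ccc(/C=C/C(=O)c4cccc(OC)c4)cc3)c2)on1`, differs from compound 2 by 3-methoxyphenyl in place of pyridin-3-yl on a carbonyl carbon. Among the measured compounds shown here, no step between two measured compounds is available, so the size of this change cannot be read from measurements. Because the limit of > 50 ug/mL in this assay, at which 1 of the 2 values shown sits, shows the only measured relative sitting at the limit, and the change touches only the ring attached to the carbonyl carbon, no step beyond the usual scatter is expected in either direction, and a reading at the limit again seems the likeliest outcome. Compound 3 is therefore expected to give about 50 ug/mL in this assay, with a plausible range from 15 ug/mL to 150 ug/mL.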

Compound 3, half-maximal cytotoxic concentration: > 100 ug/mL
Compound 3 was reported as a limit (the forecaster's own chance of this, stated with the estimate: 60%); middle value at least 2.0-fold (0.30 log units) away from the limit.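

In this assay compound 3 gives > 100 ug/mL, which is a limit and not a number. Compound 1 gives > 50 ug/mL, also a limit. Together, these two limits leave the step from compound 1 to compound 3 unreadable. The compounds shown leave open what numbers compound 1 and compound 3 would reach in this test, and where compound 2 stands.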